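A few compounds are considered here, and "the series" means these few. Any claim that something is new, unique, unknown or untested is made for them only; others in the source may bear on it.

Among the measured compounds shown here, in a functional assay on MCF7 cells (Homo sapiens) for cytotoxicity, read by MTT assay, with a stated time of 72 h (on this read-out lower numbers stand for stronger inhibition and higher numbers for weaker inhibition), compound 1 (`O=C(N/N=C/c1cccc(Br)c1)Nc1cc2c(Nc3ccc(F)c(Cl)c3)ncnc2cc1O[C@H]1CCOC1`) gives 12400 nM and compound 2 (`O=C(N/N=C/c1cc(Br)c(O)c(Br)c1)Nc1cc2c(Nc3ccc(F)c(Cl)c3)ncnc2cc1O[C@H]1CCOC1`) gives 5910 nM, the lower of the two numbers measured so far. The next change leads to compound 3 (`O=C(N/N=C/c1ccc(O)cc1O)Nc1cc2c(Nc3ccc(F)c(Cl)c3)ncnc2cc1O[C@H]1CCOC1`), with 2,4-dihydroxyphenyl in place of 3,5-dibromo-4-hydroxyphenyl on a carbon with a double bond to nitrogen. For the measured compounds named here, only one measured step bears on this, the modest 2.1-fold lower number from compound 1 to compound 2 (0.32 log units; beyond the scatter), where 3,5-dibromo-4-hydroxyphenyl replaced 3-bromophenyl. Going by the values given here, that step added a bromine and a hydroxyl together, so it does not separate the two, and no measured compound lacks bromine. The direction is therefore uncertain, but a small move back toward higher numbers in this assay is expected, no larger than the measured step. The expected step is a 1.4-fold higher number from compound 2 to compound 3 (0.16 log units; within the scatter). The estimated value for compound 3 is 8500 nM, with an expected range from 3500 nM to 22000 nM.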

Compound 3, half-maximal inhibitory concentration: 5350 nM
Compound 3: the middle estimate sits 1.6-fold (0.20 log units) above what was measured; the measured number falls inside the stated range.
By their numbers in this assay, from the lowest: compounds 3 and 2 (each within the scatter of the next); then compound 1.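

At the carbon with a double bond to nitrogen, a group without bromine, 2,4-dihydroxyphenyl, reads level with 3,5-dibromo-4-hydroxyphenyl in this assay, with a 1.1-fold lower number from compound 2 to compound 3 (0.04 log units; within the scatter), so bromine is not needed to match compound 2 among these compounds. Against 3-bromophenyl, 2,4-dihydroxyphenyl gives a 2.3-fold lower number from compound 1 to compound 3 (0.37 log units; beyond the scatter), and the two compounds at the low end of this assay both carry hydroxyl on this ring, while compound 1 carries none. No measurement shown accounts for these readings.

On these data alone, whether hydroxyl alone separates compound 2 and compound 3 from compound 1 stays open, since each of these rings differs from 3-bromophenyl in more than one way. A plain phenyl, a single hydroxyl, a methoxy group or an amine on this ring would test that reading.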